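Methyl in place of hydrogen on a hydroxamic acid inhibitor

The source may report more compounds than this note shows. Statements on the series, on what has been measured and on what is new or still open speak of the compounds shown alone.

Measured so far:
Compound 1 `O=C(CCCCCCC(=O)Nc1nnc(-c2ccco2)s1)NO` gives 880 nM in a functional assay on PC-3 cells (Homo sapiens) for inhibition, read by MTT assay; on this read-out lower numbers stand for stronger inhibition and higher numbers for weaker inhibition.
Compound 2 `N#Cc1cccc(-c2cn(CCCCCCn3cccc(/C=C/C(=O)NO)c3=O)nn2)c1` gives 600 nM in this assay.

Only these two compounds have numbers, and they are not related by a single change; compound 1 and compound 2 lie within the scatter of each other, so nothing separates them here. Compound 1 is the point of departure for compound 3 `Cc1ccc(-c2nnc(NC(=O)CCCCCCC(=O)NO)s2)o1`, which has not yet been tested. The change is small: methyl in place of hydrogen on an aromatic carbon. Among the measured compounds shown here, no measured pair shows what such a change does in this assay, so the expectation rests on the size of the change alone. For so small an addition, compound 3 is expected to give a number close to that of compound 1, with the step of a 1.2-fold lower number from compound 1 to compound 3 (0.07 log units; within the scatter) expected to stay within the scatter. Compound 3 is therefore estimated at 750 nM in this assay. For compound 3 the range is expected to run from 300 nM to 1900 nM.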

Compound 3, half-maximal inhibitory concentration: 880 nM
For compound 3 the middle estimate is 1.2-fold (0.07 log units) below the measured one; low and high end bracket the measured number.
By their numbers in this assay, from the lowest: compounds 2, 1 and 3 (each within the scatter of the next).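

Methyl in place of hydrogen, furan-2-yl to 5-methylfuran-2-yl, is the first single change that can be read in this assay, and it gives no change at the digits printed from compound 1 to compound 3 (within the scatter). This position, on an aromatic carbon next to the ring oxygen and two ring bonds from the ring atom that bears a large group, therefore takes one added carbon with nothing to separate the two compounds in this assay. No measurement at hand speaks to what lies behind this outcome.

This single pair leaves open whether an amine, a carboxylic acid or a longer chain such as propyl at the same position would also leave the number within the scatter of compound 1. It also leaves open whether methyl would behave the same way on another carbon of this ring.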